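Growth inhibition series: swapping the para substituent

This account rests on a few compounds, and the source may have more. Where it says the series, first, only, none or still open, it means among the compounds named here.

Measured so far:
- compound 1 `O=C(O)c1ccc(Nc2ccnc(SCC(=O)c3ccc(C(F)(F)F)cc3)n2)cc1`: 12%
- compound 2 `CC(=O)c1cccc(Nc2ccnc(SCC(=O)c3ccc(-c4ccccc4)cc3)n2)c1`: 25%
- compound 3 `COc1ccc(C(=O)CSc2nccc(Nc3cccc(C(C)=O)c3)n2)cc1`: 37%

In a functional assay on PC-3 cells (Homo sapiens) for inhibition, read by sulforhodamine B assay, with a stated time of 48 h, tested at 10 uM (a higher number here means more inhibition of growth at the concentration tested, a lower number less inhibition of growth), compound 3 gives the highest of the three numbers, with compound 2 next and compound 1 furthest off. Among the compounds with values here, the one single-change step, a number 12 percentage points higher from compound 2 to compound 3 (beyond the scatter), is modest. Compound 4 `CC(=O)c1cccc(Nc2ccnc(SCC(=O)c3ccc(C(F)(F)F)cc3)n2)c1` differs from compound 3 by trifluoromethyl in place of methoxy on an aromatic carbon. Within the data shown here, no measured step covers this exact change; compound 1 carries the same trifluoromethyl group but differs elsewhere, so its value only shows that this group can sit on a weak compound. On that basis a modest downward step is expected, though one within the scatter cannot be excluded: the step from compound 3 to compound 4 is estimated as a number 12 percentage points lower from compound 3 to compound 4 (beyond the scatter). Compound 4 is therefore expected to give about 25% in this assay, within 8% to 42%.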

Compound 4, percent growth inhibition at one concentration: 30%
For compound 4 the middle estimate is 5 percentage points below the measured one, and the stated range covers the measured number.
By their numbers in this assay, from the lowest: compound 1; then compounds 2, 4 and 3 (each within the scatter of the next, the first and the last beyond it).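

In this assay trifluoromethyl in place of methoxy gives a number 7 percentage points lower from compound 3 to compound 4 (within the scatter) and trifluoromethyl in place of phenyl gives a number 5 percentage points higher from compound 2 to compound 4 (within the scatter) while methoxy and phenyl themselves stand apart beyond the scatter. With trifluoromethyl held fixed, 3-acetylphenyl in place of 4-carboxyphenyl on the nitrogen gives a number 18 percentage points higher from compound 1 to compound 4 (beyond the scatter) so the low number of compound 1 does not follow from trifluoromethyl alone. Nothing available gives a reason for these steps. Still open, on these data alone, is whether an amine or a longer chain on this aromatic carbon would move the number beyond the scatter.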